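A few compounds are considered here, and "the series" means these few. Any claim that something is new, unique, unknown or untested is made for them only; others in the source may bear on it.

Compound 1 `[O-][n+]1nc(NC2CCCCC2)[n+]([O-])c2ccccc21` and compound 2 `Cc1ccc(Nc2n[n+]([O-])c3ccccc3[n+]2[O-])cc1` share the same core and differ only in the amine substituent. In a functional assay on PC-3 cells (Homo sapiens) for cytotoxicity, read by MTT assay, with a stated time of 48 h (on this read-out lower numbers stand for stronger inhibition and higher numbers for weaker inhibition), compound 1 gives 10500 nM. In this assay compound 2 gives 10300 nM, a number that stands alongside that of compound 1, the two lying within the scatter of each other. Compound 3 `[O-][n+]1nc(Nc2ccccc2)[n+]([O-])c2ccccc21` differs from compound 2 by hydrogen in place of methyl on an aromatic carbon. Going by the values given here, no measured pair shows this change, so in this assay the step from compound 2 to compound 3 is expected to be a 1.0-fold lower number from compound 2 to compound 3 (0.01 log units; within the scatter), nothing beyond the scatter. Compound 3 is therefore estimated at 10000 nM, between 4000 nM and 25000 nM.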

Compound 3, half-maximal inhibitory concentration: 17000 nM
Compound 3: middle estimate off by 1.7-fold (0.23 log units), on the low side, and the stated range covers the measured number.
By their numbers in this assay, from the lowest: compounds 2, 1 and 3 (each within the scatter of the next).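

In this assay the aromatic carbon para to a large group now has a direct comparison: hydrogen in place of methyl gives a 1.7-fold higher number from compound 2 to compound 3 (0.22 log units; within the scatter), so methyl and hydrogen at this place stand within the scatter. The group on the nitrogen also has one: phenyl in place of cyclohexyl gives a 1.6-fold higher number from compound 1 to compound 3 (0.21 log units; within the scatter), again within the scatter. No further data shown here bear on these steps. Going by these compounds, whether a chlorine or a methoxy group on that carbon, or a longer chain on the nitrogen, would give a step beyond the scatter stays open.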